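Two Ways of Swapping a Small Ring for a Branched Chain

This account rests on a few compounds, and the source may have more. Where it says the series, first, only, none or still open, it means among the compounds named here.

Four compounds sharing a common core are compared in a functional assay on CHO cells for positive allosteric modulation of metabotropic glutamate receptor 2 (Homo sapiens), with a stated time of 30 min; a higher number here means that more compound is needed for the effect, a lower number that less compound is needed. Compound 1 `CC(C)CCn1ccc(N2CCC(c3ccccc3)CC2)c(C#N)c1=O` gives 102 nM. Compound 2 `N#Cc1c(N2CCC(c3ccccc3)CC2)ccn(CCC2CC2)c1=O` gives 178 nM. Compound 3 `O=c1c(Cl)c(N2CCC(c3ccccc3)CC2)ccn1CC1CC1` gives 170 nM. The difference between the core of compound 2 and the core of compound 3 is not broken down here; their two values lie close together.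

Compounds 1 and 2 differ in one place only, described as isopropyl in place of cyclopropyl on a saturated chain carbon, two bonds along the chain from an aromatic nitrogen. That change gave a 1.7-fold lower number from compound 2 to compound 1 (0.24 log units; within the scatter), a step small enough to count as noise.

Compound 4 `CC(C)Cn1ccc(N2CCC(c3ccccc3)CC2)c(Cl)c1=O` has not yet been measured. It is related to compound 3 by isopropyl in place of cyclopropyl on a saturated chain carbon bound to an aromatic nitrogen. For the measured compounds named here, this is the same kind of change as the one from compound 2 to compound 1, but not the same: in compound 1 the isopropyl sits on a saturated chain carbon two bonds along the chain from an aromatic nitrogen, whereas in compound 4 it sits on a saturated chain carbon bound directly to the aromatic nitrogen, so the chain is one carbon shorter.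

Taking the earlier step as the only guide, a step of a 1.3-fold lower number from compound 3 to compound 4 (0.12 log units; within the scatter) is expected, so compound 4 is estimated at 130 nM, with a plausible range from 60 nM to 280 nM. This expectation rests on compound 3 giving 170 nM and on the earlier change giving a 1.7-fold lower number from compound 2 to compound 1 (0.24 log units; within the scatter), while the shortened chain adds uncertainty.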

Compound 4, half-maximal effective concentration: 195 nM
Beside the measured number, compound 4's estimate is 1.5-fold (0.18 log units) below it, within the range that was stated.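

The new step is a 1.1-fold higher number from compound 3 to compound 4 (0.06 log units; within the scatter) and lies within the scatter, so the cyclopropyl and isopropyl compounds on this core cannot be told apart. Set beside the step on the other core, this result gives no sign that the swap behaves differently from one core to the other: the same change on two cores in this assay, a 1.7-fold lower number (0.24 log units; within the scatter) from compound 2 to compound 1 and a 1.1-fold higher number (0.06 log units; within the scatter) from compound 3 to compound 4, 2.0-fold (0.30 log units) apart, within the scatter of two such steps. What this shows is modest: on both cores, the branched isopropyl can stand in for the cyclopropyl ring with no change that rises above the scatter, but it does not show that the swap has a fixed effect that can be carried to a further core, since both steps are too small to separate from noise, and the chain differs by one carbon between the two pairs.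

The compounds shown leave open whether any group in this place would give a step beyond the scatter, for instance a longer chain, a benzyl group or a chain ending in an amine. They also leave open how much the core alone contributes, as no two of these compounds carry the same chain on the two different cores.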